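This account rests on a few compounds, and the source may have more. Where it says the series, first, only, none or still open, it means among the compounds named here.

Measured so far in a physicochemical assay for lipophilicity, using the shake flask method, measured as octanol-water partition, at pH 7.4; a lower number here means a more polar compound, a higher number a more lipophilic compound
- Compound 1 `CC(C)n1nc(-c2ccnc3[nH]c(C4CCN(CC(=O)N(C)C)CC4)cc23)ccc1=O` gives 2
- Compound 2 `CC(C)Cn1cc(-c2ccnc3[nH]c(C4CCN(CC(=O)N(C)C)CC4)cc23)ccc1=O` gives 2
- Compound 3 `CC(C)n1cc(-c2ccnc3[nH]c(C4CCN(CC(=O)N(C)C)CC4)cc23)ccc1=O` gives 1.9

Compound 3 stands at 1.9 and cannot be told apart from the other two compounds, whose steps to it stay within the usual scatter of repeated measurements.

Compound 4 (`CCn1cc(-c2ccnc3[nH]c(C4CCN(CC(=O)N(C)C)CC4)cc23)ccc1=O`) turns isopropyl to ethyl, which means hydrogen in place of methyl on a saturated chain carbon bound to an aromatic nitrogen and a saturated chain carbon. The rest of the structure stays the same.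

Among the compounds with values here, the closest guide is a step of the same kind, isopropyl in place of isobutyl on an aromatic nitrogen: a number 0.10 log units lower from compound 2 to compound 3 (within the scatter) and so the one shortening of this group measured so far hardly shows. The other measured step, a number 0.10 log units lower from compound 1 to compound 3 (within the scatter) concerns an exchange of aromatic rings and says little about this change. Three compounds are a thin base, so the range must stay generous.

A small move toward a lower number in this assay is expected, perhaps none beyond the scatter. The estimated a number 0.20 log units lower from compound 3 to compound 4 (within the scatter) is of that modest size. Compound 4 is expected at 1.7 in this assay with an estimated range of 1.4 to 2 around that figure.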

Compound 4, distribution coefficient: 1.2
Compound 4: middle estimate off by 0.50 log units, on the high side; the whole stated range lies above it.
By their numbers in this assay, from the lowest: compound 4; then compounds 3, 1 and 2 (each within the scatter of the next).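

Taking the isopropyl on the aromatic nitrogen down to ethyl gives, in this assay, a number 0.70 log units lower from compound 3 to compound 4 (beyond the scatter), while the earlier shortening of isobutyl to isopropyl gave only a number 0.10 log units lower from compound 2 to compound 3 (within the scatter). So among these three compounds the number does not fall evenly as the chain on this nitrogen shortens: the loss of one methyl hardly shows in one step and clearly shows in the next, and the full shortening gives a number 0.80 log units lower from compound 2 to compound 4 (beyond the scatter). Compound 4 also now stands clearly apart from the compound with the other aromatic ring and the isopropyl group, with a number 0.80 log units lower from compound 1 to compound 4 (beyond the scatter), although nothing shown gives a reason for the size of this drop.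

From the compounds shown here alone, whether a plain methyl on this aromatic nitrogen would take the number lower still, or a cyclopropyl group would sit with the isopropyl or with the ethyl compound, remains open. Also open, going by these compounds, is whether an ethyl group on the ring of compound 1 would bring the same drop as it does on the ring of compound 3.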